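Acyl chain length on the piperidine amide series

A few compounds are considered here, and "the series" means these few. Any claim that something is new, unique, unknown or untested is made for them only; others in the source may bear on it.

Compound 3 `CC(=O)NC1CCCN(S(=O)(=O)c2ccc(F)cc2)C1` gives 1 mg/kg in a functional assay on the whole organism with Mus musculus as the target, with a stated time of 30 min; on this read-out higher numbers stand for an effect only at larger amounts of compound and lower numbers for an effect already at smaller amounts. Compound 1 `CC(C)S(=O)(=O)NC1CCCN(S(=O)(=O)c2ccc(F)cc2)C1` gives 1 mg/kg, and the step of no change at the digits printed from compound 1 to compound 3 (within the scatter) is a change of acyl group with no effect beyond the scatter; together compound 1 and compound 3 hold the highest numbers of the three. Compound 2 `CCC(=O)N1CCN(S(=O)(=O)c2ccc(F)cc2)CC1`, a different core, gives 0.01 mg/kg, a much lower number. Compound 4 `CCC(=O)NC1CCCN(S(=O)(=O)c2ccc(F)cc2)C1` differs from compound 3 by methyl in place of hydrogen on a saturated chain carbon bound to a carbonyl carbon. Going by the values given here, no measured step follows this exact change; the only step touching the amide, from compound 1 to compound 3, showed nothing beyond the scatter, so a step without a shift beyond the scatter is expected, no change at the digits printed from compound 3 to compound 4 (within the scatter). Compound 4 is thus estimated at 1 mg/kg. The range for compound 4 is expected to run from 0.3 mg/kg to 3 mg/kg.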

Compound 4, minimum effective dose: 1 mg/kg
For compound 4 middle estimate and measured number coincide at the digits printed; measured number inside the range.
By their numbers in this assay, from the lowest: compound 2; then compounds 1, 3 and 4 (each within the scatter of the next).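

In this assay, going by these compounds alone, the step of methyl in place of hydrogen on a saturated chain carbon bound to a carbonyl carbon gives no change at the digits printed from compound 3 to compound 4 (within the scatter) and is the first reading of chain length on this amide. Propanoyl in place of isopropylsulfonyl on the amine nitrogen gives no change at the digits printed from compound 1 to compound 4 (within the scatter) on the same core, so neither acetyl nor propanoyl separates from the sulfonamide here. No data at hand explain this flat result. Still open, as far as these compounds go, is whether butanoyl or a longer chain would shift the number beyond the scatter. From the compounds shown here alone, a carboxylic acid or an amine on the acyl chain is equally open.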